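A few compounds are considered here, and "the series" means these few. Any claim that something is new, unique, unknown or untested is made for them only; others in the source may bear on it.

The account concerns three measured compounds and one still to be measured, all judged in a toxicity assay on THP-1 cells (Homo sapiens) for inhibition; a lower number here means that less compound is tolerated, a higher number that more compound is tolerated. Compound 1 `Cn1c(-c2cccc(Br)c2)cnc1NC(=O)c1ccc(F)cc1` reaches only a limit of this assay, recorded as > 50000 nM. Compound 2 `COc1ccc(-c2cnc(NC(=O)c3ccccc3OC)n2C)cc1` also reaches only a limit, recorded as > 100000 nM. For the measured compounds named here, compound 3 `O=C(Nc1ncc(-c2ccccc2)o1)c1ccc(F)cc1` is the single compound with a number, giving 17000 nM in this assay. Where compound 2 stands is therefore a limit and not a number: it sits at the limit of > 100000 nM in this assay, at which 1 of the 3 values shown sits. Compound 1 sits at a second limit, (the limit of > 50000 nM in this assay, at which 1 of the 3 values shown sits). Going by the values given here, no two measured compounds differ in a single place, so no measured step is available to guide the next change.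

Compound 4 `COc1ccc(-c2cnc(NC(=O)c3cnc[nH]3)n2C)cc1` differs from compound 2 in one place, (1H-imidazol-5-yl in place of 2-methoxyphenyl on a carbonyl carbon). Among the compounds with values here, with no measured step to lean on, the expectation for this change rests on compound 2 alone, whose value in this assay is a limit. The step from compound 2 to compound 4 is expected to be a number no higher from compound 2 to compound 4 (the limit leaves the size open), that is, no change beyond the usual scatter. Compound 4 is accordingly expected to give about 100000 nM in this assay, with a range from 30000 nM to 300000 nM, and most likely again only a limit.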

Compound 4, half-maximal cytotoxic concentration: > 100000 nM
Compound 4 ended at the assay's limit (the forecaster's own chance of this, stated with the estimate: 70%); the middle value lies on the limit itself.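

Compound 2 and compound 4 both stand at the same limit of this assay: the limit of > 100000 nM in this assay, at which 2 of the 4 values shown sit. For the compounds shown here, with both values being limits, no step between these two compounds can be read. The compounds shown leave open whether 1H-imidazol-5-yl in place of 2-methoxyphenyl on a carbonyl carbon changes the tolerated concentration at all.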